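Hydroxy to nitro at the limit of the assay

The source may hold more compounds than are shown below. What is called first, only, known or untested is meant among the compounds shown, and "the series" means these compounds.

Three compounds have readings in a functional assay on HL-60 cells (Homo sapiens) for antiproliferative activity, read by MTT assay (a higher number here means a weaker inhibitor, a lower number a stronger inhibitor), and none gives an exact number. Compound 1 `O=C(N/N=C/c1ccccc1)c1cn(C2CC2)c2cc(N/N=C/c3ccccc3)c(F)cc2c1=O` reads as a limit (<= 25000 nM). Compound 2 `COc1cc(/C=N/NC(=O)c2cn(C3CC3)c3cc(N/N=C/c4cc(OC)c(OC)c(OC)c4)c(F)cc3c2=O)cc(OC)c1OC` also reads as a limit (<= 25000 nM). Compound 3 `O=C(N/N=C/c1ccccc1O)c1cn(C2CC2)c2cc(N3CCNCC3)c(F)cc2c1=O` likewise reads as a limit (<= 25000 nM). Compound 3 therefore has no exact place in the series, as the shared reading shows (the limit of <= 25000 nM in this assay, at which 3 of the 3 values shown sit). Compound 4 `O=C(N/N=C/c1ccccc1[N+](=O)[O-])c1cn(C2CC2)c2cc(N3CCNCC3)c(F)cc2c1=O` carries nitro in place of hydroxy on an aromatic carbon, ortho to a large group, so 2-hydroxyphenyl becomes 2-nitrophenyl (nitro in place of hydroxy on an aromatic carbon). No measured step sizes this change. A small expected shift toward stronger inhibition is estimated (a step that the limit leaves unreadable from compound 3 to compound 4). For compound 4 the expected value is 15000 nM (estimated range 4000 nM to 25000 nM).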

Compound 4, half-maximal inhibitory concentration: <= 25000 nM
Compound 4: no number, only a limit; the forecaster's own chance of this, stated with the estimate: 50%; the middle value lies beyond the limit too.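

No step from compound 3 to compound 4 can be read in this assay, as both compounds sit at the same limit: the limit of <= 25000 nM in this assay, at which 4 of the 4 values shown sit.

The compounds shown leave open whether 2-hydroxyphenyl and 2-nitrophenyl differ at all in this assay.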